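Benzyl to benzoyl: working notes on the series

The source may hold more compounds than are shown below. What is called first, only, known or untested is meant among the compounds shown, and "the series" means these compounds.

Values from a functional assay on SW480 cells (Homo sapiens) for antiproliferative activity, read by MTT assay, with a stated time of 48 h (a lower number here means a stronger inhibitor, a higher number a weaker inhibitor), follow.

compound 1 `CCCCCCCCCCC(CCO)n1cnc2c(Cl)ncnc21` gives 3160 nM
compound 2 `O=C(OCC(CCO)n1cnc2c(Cl)nc(F)nc21)c1ccccc1` gives 7240 nM
compound 3 `OCCC(COCc1ccccc1)n1cnc2c(Cl)ncnc21` gives > 50000 nM (a limit, not a number)

Compound 3 stands at the limit of > 50000 nM in this assay, at which 1 of the 3 values shown sits, and so has no number of its own, only a limit.

Compound 4 `O=C(OCC(CCO)n1cnc2c(Cl)ncnc21)c1ccccc1` is still unmeasured. It carries benzoyl in place of benzyl on an oxygen on a saturated carbon and is otherwise the same as compound 3.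

Among the measured compounds shown here, no measured pair differs in one place only, so no measured step gives the size of this change in this assay directly. The nearest guide is compound 2, which also carries benzoyl on an oxygen on a saturated carbon and gives 7240 nM as a real number. On these data alone, on that ground a move towards a lower number is expected, and one that is larger than the usual scatter, though its full size stays open with a limit at one end. The expected change is an at least 5.0-fold lower number from compound 3 to compound 4 (0.69 log units; beyond the scatter) in this estimate.

For compound 4 the estimated value is 10000 nM with an expected range from 3000 nM to 35000 nM in this assay once it is measured.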

Compound 4, half-maximal inhibitory concentration: > 50000 nM
Compound 4: a limit, no number; the forecaster's own chance of this, stated with the estimate: 15%; middle value at least 5.0-fold (0.69 log units) away from the limit.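

Compound 3 and compound 4 both give only a limit in this assay, so the step with benzoyl in place of benzyl on an oxygen on a saturated carbon cannot be read, and the result gives no sign that benzoyl improves on benzyl at this position: the limit of > 50000 nM in this assay, at which 2 of the 4 values shown sit.

Among the compounds shown here, the one readable step lies elsewhere, on an aromatic carbon, where hydrogen in place of fluoro gives an at least 6.9-fold higher number from compound 2 to compound 4 (0.83 log units; beyond the scatter). With benzoyl on the oxygen in both compounds, this pair shows that benzoyl alone does not bring a value in the range of compound 2, since in this pair the measured number goes with the fluoro compound only.

On these data alone, it remains open whether fluoro on that aromatic carbon would also bring a measurable number with benzyl on the oxygen, and the size of any benzyl to benzoyl change stays unknown. Also open, as far as these compounds go, is how an amine in place of fluoro on the aromatic carbon would read in this assay, and compound 1 differs from the others in more than one place, so it offers no guide to either question.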